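Aminomethyl-oxetane ether in place of ethoxy

The compounds below may be only part of what the source reports. "The series", "measured", "known", "first", "only" and "open" are said of these compounds alone.

Compound 1, `CN1CC(NC(=O)c2cc(-c3ccc(NS(=O)(=O)c4cccc(Cl)c4Cl)cc3)nc3[nH]ncc23)C1`: < 1 nM
Compound 2, `CCOc1nc(-c2ccc(NS(=O)(=O)c3cc(Cl)ccc3F)cc2)nc2[nH]nc(C)c12`: 23 nM

Of the compounds shown here, two have been measured in an assay for inhibition of serine/threonine-protein kinase Sgk1 (Homo sapiens), with stated times of 30 min and 60 min, in the presence of a further agent that is not named here; on this read-out lower numbers stand for stronger inhibition and higher numbers for weaker inhibition. For compound 1 the read-out is a limit of the assay, (the limit of < 1 nM in this assay, at which 1 of the 2 values shown sits), and not a number. Among the measured compounds shown here, compound 2 gives 23 nM in this assay, the only number in this set, so compound 2 stands as the sole point of reference. For the measured compounds named here, no step between two measured compounds differing in one place is available.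

Compound 3, `Cc1n[nH]c2nc(-c3ccc(NS(=O)(=O)c4cc(Cl)ccc4F)cc3)nc(OCC3(CN)COC3)c12`, has not yet been measured. It differs from compound 2 by 3-(aminomethyl)oxetan-3-yl in place of methyl on a saturated chain carbon bound to an oxygen on an aromatic ring. Going by the values given here, with no measured step of comparable kind to lean on, the size of the change is uncertain; a moderate gain in inhibition is expected, well within the order of the change from compound 2 to compound 3, written as a 2.3-fold lower number from compound 2 to compound 3 (0.36 log units; beyond the scatter). Compound 3 is therefore estimated at 10 nM, with a range from 2 nM to 60 nM.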

Compound 3, half-maximal inhibitory concentration: 1 nM
The estimate for compound 3 lay 10-fold (1.00 log units) above the measured number, and the stated range ends above it.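

In this assay, among the compounds shown here, 3-(aminomethyl)oxetan-3-yl in place of methyl on a saturated chain carbon bound to an oxygen on an aromatic ring gives a 23-fold lower number from compound 2 to compound 3 (1.36 log units; beyond the scatter), a large step and the first comparison in this set of two compounds that differ in one place. It shows that this position accepts a far larger group than methyl, one that also brings a four-membered ring and a hydrogen-bond donor, and that inhibition grows strongly with this change. Compound 1 sits at a limit of the assay, which marks how little room remains for reading any stronger inhibition: the limit of < 1 nM in this assay, at which 1 of the 3 values shown sits.

The compounds shown do not separate the share of the amine from that of the oxetane ring. As far as these compounds go, it remains open whether an oxetan-3-yl group without the aminomethyl, a simple aminoethyl chain or a carboxylic acid at the same place would give a comparable step.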